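A Double Bond at the Chain End of Compound 3

This account rests on a few compounds, and the source may have more. Where it says the series, first, only, none or still open, it means among the compounds named here.

Measured in a functional assay on A549 cells (Homo sapiens) for inhibition, read by colorimetric assay and MTT assay, with a stated time of 72 h; a lower number here means a stronger inhibitor, a higher number a weaker inhibitor:
- Compound 1 `C=CCCCCOc1ccc(F)cc1-c1cnc(OCCC=C)n1C`: 61000 nM
- Compound 2 `C=CCCCCOc1ccccc1-c1cnc(OCCCC=C)n1C`: 3000 nM
- Compound 3 `CCCCCCOc1ncc(-c2ccccc2OC)n1C`: 37000 nM

Among these three compounds, compound 3 sits at the high end of the numbers in this assay, together with compound 1. The two values lie within the usual scatter of each other and cannot be told apart. Compound 2 stands apart from compound 3 by a margin well beyond that scatter.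

The next compound to be tested is compound 4 `C=CCCCCOc1ncc(-c2ccccc2OC)n1C`. Its difference from compound 3 is vinyl in place of ethyl on a saturated chain carbon, four bonds along the chain from an oxygen on an aromatic ring. The same difference, cut one bond further out, reads pentyl to pent-4-en-1-yl.

For the measured compounds named here, no pair of measured compounds isolates this change, so the data offer no direct guide to it. Compound 1 and compound 2 both carry chains ending in a double bond, yet compound 1 gives 61000 nM and compound 2 gives 3000 nM. Such a chain end therefore does not settle the number on its own. Only a small step is expected, most likely none beyond the scatter, with a slight lean toward a lower number.

The estimated change is a 1.3-fold lower number from compound 3 to compound 4 (0.12 log units; within the scatter). The value expected for compound 4 is 28000 nM, with an estimated range of 10000 nM to 65000 nM.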

Compound 4, half-maximal inhibitory concentration: 5000 nM
Estimate against measurement, compound 4: 5.6-fold (0.75 log units) above, and the stated range ends above it.
By their numbers in this assay, from the lowest: compounds 2 and 4 (each within the scatter of the next); then compounds 3 and 1 (each within the scatter of the next).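

For this assay the swap of ethyl for vinyl, on a saturated chain carbon four bonds along the chain from an oxygen on an aromatic ring, gives a 7.4-fold lower number from compound 3 to compound 4 (0.87 log units; beyond the scatter), and this step lies beyond the usual scatter. It is the first comparison among these compounds that differs in one place only, and it shows that this position responds to the change: the double bond alone, with the rest of the structure held fixed, moves the number by more than repeated measurements would. No measurement at hand bears on the reason for this step.

The compounds shown leave open whether the same swap gives a step of similar size in another compound, as no second pair among them carries this change. They also leave open how the number would respond at this place to a longer chain, to an amine or to a carboxylic acid.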